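The source may report more compounds than this note shows. Statements on the series, on what has been measured and on what is new or still open speak of the compounds shown alone.

Measured compounds:
compound 1, `COc1ccc(OC)c(/C=C/c2nnc(Nc3ccc(Cl)cc3)o2)c1` — > 100000 nM
compound 2, `COc1ccc(OC)c(/C=C/C(=O)N/N=C/c2ccc(Cl)cc2)c1` — 6700 nM

In a functional assay on M14 cells (Homo sapiens) for antiproliferative activity, read by sulforhodamine B assay, with a stated time of 48 h (a higher number here means a weaker inhibitor of growth, a lower number a stronger inhibitor of growth), compound 1 reaches only > 100000 nM, which is a limit of the assay and not a number. In this assay, going by the values given here, compound 2 gives 6700 nM, the only actual number among the values shown. Among the compounds with values here, the one other value, that of compound 1, is the limit of > 100000 nM in this assay, at which 1 of the 2 values shown sits. Within the data shown here, no step between two measured compounds is available, so the move to compound 3, `COc1ccc(OC)c(/C=C/C(=O)N/N=C/c2ccccc2)c1`, rests on the structural change alone: hydrogen in place of chloro on an aromatic carbon. Without a measured precedent for this change, the step expected in this assay from compound 2 to compound 3 is a modest weakening, possibly no larger than the scatter, namely a 2.1-fold higher number from compound 2 to compound 3 (0.32 log units; beyond the scatter). Compound 3 is accordingly estimated at 14000 nM, with a range from 5000 nM to 45000 nM.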

Compound 3, concentration for total growth inhibition: 6770 nM
For compound 3 the middle estimate is 2.1-fold (0.32 log units) above the measured one; the measured number falls inside the stated range.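

Replacing chloro with hydrogen gives a 1.0-fold higher number from compound 2 to compound 3 (0.00 log units; within the scatter) in this assay and so leaves the read-out where it was. Going by these compounds alone, this is the first direct reading of this position, the aromatic carbon para to a large group, and 4-chlorophenyl and phenyl cannot be told apart in this assay. The chlorine atom is therefore not required for compound 3 to keep a value matching that of compound 2, and nothing shown here gives a cause for this result.

The compounds shown leave open whether this position stays as indifferent with an amine, a hydroxyl or a carboxylic acid in place of the hydrogen. They also do not tell whether the two methoxy groups on the other aromatic ring matter, for example if a hydroxyl replaced either of them.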